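The compounds below may be only part of what the source reports. "The series", "measured", "known", "first", "only" and "open" are said of these compounds alone.

Measured so far in an assay on isolated protein (strain Sprague-Dawley) for inhibition of Amine oxidase [flavin-containing] B (Rattus norvegicus), read by spectrophotometry, with a stated time of 5 min; a higher number here means a weaker inhibitor, a lower number a stronger inhibitor:
compound 1 `COc1cc(=O)oc2cc(OCc3cccc(Br)c3)ccc12` gives 5.75 nM;
compound 2 `CC(C)Oc1cc(=O)oc2cc(OCc3cccc(Cl)c3)ccc12` gives 24500 nM.

Compound 2 has the highest of the two numbers; compound 1, which differs from it in more than one place, gives a far lower value, and no single step between the two is shown. Compound 3 `CNc1cc(=O)oc2cc(OCc3cccc(Cl)c3)ccc12` carries the change (methylamino in place of isopropoxy on an aromatic carbon). Since compound 1 reaches 5.75 nM with a smaller group in that region, compound 3 is expected to move well below compound 2, a step of an 82-fold lower number from compound 2 to compound 3 (1.91 log units; beyond the scatter), though the size is uncertain. Compound 3 is estimated at 300 nM, in the range 30 nM to 3000 nM.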

Compound 3, half-maximal inhibitory concentration: 8.71 nM
Compound 3: middle estimate off by 34-fold (1.54 log units), on the high side; the measured number lies below the stated range.
By their numbers in this assay, from the lowest: compounds 1 and 3 (each within the scatter of the next); then compound 2.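

In this assay, the aromatic carbon opposite the ring oxygen proves highly sensitive to its substituent: methylamino in place of isopropoxy gives a 2800-fold lower number from compound 2 to compound 3 (3.45 log units; beyond the scatter). This is the only step shown that isolates this position, and it shows that the isopropoxy group is not needed for a low number. No available evidence accounts for the size of this step. The compounds shown leave open whether the step follows the shorter chain or the nitrogen in place of oxygen, since both change together. As far as these compounds go, how an unsubstituted amine or an ethylamino group would read here also remains open.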